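Aryl replacement on the fused core: compound 4

The compounds below may be only part of what the source reports. "The series", "measured", "known", "first", "only" and "open" are said of these compounds alone.

Measured so far:
compound 1 `CC#CC(CC(=O)O)c1ccc(OCc2ccn3cc(-c4ccc(C5CCCCC5)cc4)nc3c2)cc1` 559 nM
compound 2 `CC#CC(CC(=O)O)c1ccc(OCc2ccc3nc(-c4ccc(C5CCCCC5)cc4)cn3c2)cc1` 417 nM
compound 3 `CC#CC(CC(=O)O)c1ccc(OCc2ccc3nc(-c4ccc(C)cc4C)cn3c2)cc1` 316 nM

In an assay on isolated protein for agonist activity at Free fatty acid receptor 1 (Homo sapiens) (on this read-out higher numbers stand for an effect only at larger amounts of compound and lower numbers for an effect already at smaller amounts), compound 1 gives the highest of the three numbers, though compound 2 and compound 3 lie within the scatter of it. Compound 4 `CC#CC(CC(=O)O)c1ccc(OCc2ccn3cc(-c4cc(F)ccc4F)nc3c2)cc1` differs from compound 1 by 2,5-difluorophenyl in place of 4-cyclohexylphenyl on an aromatic carbon. Within the data shown here, the one measured step that bears on this, a 1.3-fold lower number from compound 2 to compound 3 (0.12 log units; within the scatter), swapped the same 4-cyclohexylphenyl for a different aryl group and stayed within the scatter. Among the measured compounds shown here, no step with 2,5-difluorophenyl itself is on hand. For compound 4 the expected change is therefore small, a 1.2-fold lower number from compound 1 to compound 4 (0.09 log units; within the scatter), with no direction that the data support beyond the scatter. Compound 4 is estimated at 450 nM in this assay, between 150 nM and 1400 nM.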

Compound 4, half-maximal effective concentration: 639 nM
Compound 4: the middle estimate sits 1.4-fold (0.15 log units) below what was measured, and the stated range covers the measured number.
By their numbers in this assay, from the lowest: compounds 3, 2, 1 and 4 (each within the scatter of the next, the first and the last beyond it).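

In this assay 2,5-difluorophenyl in place of 4-cyclohexylphenyl gives a 1.1-fold higher number from compound 1 to compound 4 (0.06 log units; within the scatter) on the core of compound 1. At this aromatic carbon, then, the non-aromatic carbon ring can be lost and two fluorine atoms added, with 12 heavy atoms going to 8, without a step beyond the scatter. No evidence on hand accounts for this. From the compounds shown here alone, whether an amine or a longer chain on this carbon would move the number beyond the scatter stays open. So does whether 2,5-difluorophenyl gives a similar result on the core of compound 2.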